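This account rests on a few compounds, and the source may have more. Where it says the series, first, only, none or still open, it means among the compounds named here.

Measured so far:
- compound 1, `O=C(Nc1cc(C(F)(F)F)cc(C(F)(F)F)c1)c1cc(Cl)c(-c2ccccc2)cc1O`: 430 nM
- compound 2, `N#Cc1ccc(NC(=O)c2cc(Cl)ccc2O)c(Cl)c1`: 860 nM

Two compounds on the shared core have numbers in a functional assay on KG-1 cells (Homo sapiens) for cytotoxicity, read by luminescence and CellTiter-Glo, with a stated time of 3 days; on this read-out lower numbers stand for stronger inhibition and higher numbers for weaker inhibition. Compound 1 gives 430 nM and compound 2 gives 860 nM. For the measured compounds named here, the gap between these two values sits within the usual scatter of repeated measurements, so on this read-out compound 2 is not separated from compound 1, and no ranking of the pair is supported.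

Compound 3, `O=C(Nc1ccc(OC(F)(F)F)cc1Cl)c1cc(Cl)ccc1O`, keeps the core of compound 2 and changes one substituent:
trifluoromethoxy in place of cyano on an aromatic carbon
The replacing group sits on an aromatic carbon of a six-membered aromatic ring of carbon only, meta to a chloro group and para to a large group. Going by the values given here, no pair of measured compounds that differ in one place is available, so the size of this step in this assay cannot be read from the data; the expectation is for no step beyond the scatter in either direction. Compound 3 is expected to come in near 900 nM, with a range from 350 nM to 2500 nM. The estimated step of a 1.0-fold higher number from compound 2 to compound 3 (0.02 log units; within the scatter) is therefore taken as flat.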

Compound 3, half-maximal inhibitory concentration: 620 nM
Beside the measured number, compound 3's estimate is 1.5-fold (0.16 log units) above it; measured number inside the range.
By their numbers in this assay, from the lowest: compounds 1, 3 and 2 (each within the scatter of the next).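

Working notes: in this assay, trifluoromethoxy in place of cyano on an aromatic carbon, meta to a chloro group and para to a large group, gives a 1.4-fold lower number from compound 2 to compound 3 (0.14 log units; within the scatter), the first step in the series between compounds that differ in one place. The exchange brings in 5 heavy atoms for 2, with the hydrogen-bond acceptor count and the absence of net charge unchanged, and the read-out does not separate the pair, so this position accepts this particular swap without a resolved effect on the number in this assay. No supporting data bear on the reason for this flat step, and none addresses what either group does here.

The compounds shown leave open whether the position stays flat for groups of a different type, such as an amine, a carboxylic acid or a longer alkyl chain, since the two groups compared here are both uncharged. They also leave open whether the same swap would stay flat without the chloro group on that ring, and compound 1 differs from compound 3 in more than one place, so it gives no answer.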